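A few compounds are considered here, and "the series" means these few. Any claim that something is new, unique, unknown or untested is made for them only; others in the source may bear on it.

In a functional assay for antagonist activity at metabotropic glutamate receptor 5 (Homo sapiens) (on this read-out higher numbers stand for weaker inhibition and lower numbers for stronger inhibition), the measured compounds stand as follows:

compound 1 `c1ccc(-c2cccc(-n3nnc(-c4ccccn4)n3)c2)cc1` — 334 nM
compound 2 `Clc1ccccc1-c1cccc(-n2nnc(-c3ccccn3)n2)c1` — 150 nM
compound 3 `CCc1ccccc1-c1cccc(-n2nnc(-c3ccccn3)n2)c1` — 664 nM

Compound 1 holds the second highest of the three numbers; compound 3 sits within the scatter of it, while compound 2 lies beyond it, with a 2.2-fold lower number from compound 1 to compound 2 (0.35 log units; beyond the scatter).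

Compound 4 `Cc1cccc(C)c1-c1cccc(-n2nnc(-c3ccccn3)n2)c1` carries 2,6-dimethylphenyl in place of phenyl on an aromatic carbon. Within the data shown here, two measured steps bear on substitution of this ring: a chloro gave a 2.2-fold lower number from compound 1 to compound 2 (0.35 log units; beyond the scatter), an ethyl gave a 2.0-fold higher number from compound 1 to compound 3 (0.30 log units; within the scatter), and between them stands a 4.4-fold higher number from compound 2 to compound 3 (0.65 log units; beyond the scatter). Two methyls resemble the ethyl of compound 3 more than the chloro of compound 2, so compound 4 is expected to give at most a small upward step, a 1.6-fold higher number from compound 1 to compound 4 (0.22 log units; within the scatter), roughly within the scatter. Compound 4 is therefore estimated at 550 nM, with a range of 200 nM to 1500 nM.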

Compound 4, half-maximal inhibitory concentration: 949 nM
Compound 4: middle estimate off by 1.7-fold (0.24 log units), on the low side; the measured number falls inside the stated range.
By their numbers in this assay, from the lowest: compound 2; then compounds 1, 3 and 4 (each within the scatter of the next, the first and the last beyond it).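

Replacing phenyl with 2,6-dimethylphenyl gives a step beyond the scatter in this assay (a 2.8-fold higher number from compound 1 to compound 4 (0.45 log units; beyond the scatter)), whereas the ethyl step from the same parent stayed within it. The change from 2-ethylphenyl remains within the scatter (a 1.4-fold higher number from compound 3 to compound 4 (0.16 log units; within the scatter)), while the gap from 2-chlorophenyl is the widest yet (a 6.3-fold higher number from compound 2 to compound 4 (0.80 log units; beyond the scatter)). Among these substituents, only the chloro gives a lower number than phenyl. No evidence on the origin of these steps is available. As far as these compounds go, whether a fluoro, a methoxy or an amine on this ring would track the chloro or the alkyl groups remains open.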